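Cytotoxicity of a quinoline urea series on rat muscle cells

This account rests on a few compounds, and the source may have more. Where it says the series, first, only, none or still open, it means among the compounds named here.

Measured compounds:
- compound 1, `COc1cc(NC(C)CCCNC(=O)NC2CCCC2)c2ncccc2c1`: "not determined" (no result reported) in an ADME assay on L6 cells (Rattus norvegicus) for cytotoxicity, read by resazurin assay, with a stated time of 70 h; on this read-out lower numbers stand for stronger inhibition and higher numbers for weaker inhibition
- compound 2, `COc1cc(NC(C)CCCNC(=O)NC2CCCCC2)c2ncccc2c1`: "not determined" (no result reported)
- compound 3, `COc1cc(NC(C)CCCNC(=O)NNC(=O)/C=C/c2ccc(Cl)cc2)c2ncccc2c1`: 7300 nM

Three compounds share one core, a methoxy-substituted quinoline bearing a branched amine chain that ends in a urea. In compound 1 and compound 2 the urea carries a cyclopentyl or a cyclohexyl group; in this assay compound 1 gives "not determined" (no result reported) and compound 2 gives "not determined" (no result reported). Compound 3 carries instead an acyl hydrazide built on a chlorinated cinnamoyl group, and in this assay compound 3 gives 7300 nM. Within the data shown here, since it is the only number in hand, compound 3 stands alone as the sole point of reference, and no step between two measured compounds can be drawn.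

Compound 4, `COc1cc(NC(C)CCCNC(=O)NNC(=O)Nc2cccc(C(F)(F)F)c2)c2ncccc2c1`, departs from compound 3 at the far end of the chain: (3-(trifluoromethyl)phenyl)amino in place of 2-(4-chlorophenyl)ethenyl on a carbonyl carbon. The hydrazide linkage is kept, so the change is confined to the terminal aromatic group and its link.

Among the measured compounds shown here, with no measured step to lean on, the expectation for compound 4 is a step of a 1.2-fold higher number from compound 3 to compound 4 (0.09 log units; within the scatter), that is, no shift beyond the usual scatter. Compound 4 is estimated at 9000 nM, within a range of 3000 nM to 35000 nM.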

Compound 4, half-maximal inhibitory concentration: 32100 nM
The estimate for compound 4 lay 3.6-fold (0.55 log units) below the measured number; measured number inside the range.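

In this assay, replacing 2-(4-chlorophenyl)ethenyl with (3-(trifluoromethyl)phenyl)amino on the carbonyl carbon gives a 4.4-fold higher number from compound 3 to compound 4 (0.64 log units; beyond the scatter), so with the hydrazide linkage kept, the group at the far end of the chain still changes this read-out beyond the usual scatter. The swap changes several things at once, as the double bond outside the aromatic ring and the chlorine leave while an amino link with one hydrogen-bond donor and a trifluoromethyl group enter, and this single step cannot assign the shift to any one of them. No measurement shown here accounts for the shift.

Going by these compounds, it remains open whether the shift follows the new amino link or the exchange of chlorine for trifluoromethyl, a question that a (4-chlorophenyl)amino group on the same carbonyl carbon could help to separate. Also open, on these data alone, are how a terminal amine or a carboxylic acid at this position would read out, and how the hydrazide compounds compare with the cyclopentyl and cyclohexyl ureas, whose steps cannot be read.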